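A Methyl Group Removed, With Little Change Expected

A few compounds are considered here, and "the series" means these few. Any claim that something is new, unique, unknown or untested is made for them only; others in the source may bear on it.

In an ADME assay on WI-38 cells (Homo sapiens) for cytotoxicity, read by sulforhodamine B assay, with a stated time of 24 h (on this read-out lower numbers stand for stronger inhibition and higher numbers for weaker inhibition), compound 1 (`O=C1Nc2ccc(S(=O)(=O)N3CCOCC3)cc2/C1=N/c1ccc(O)cc1`) gives 259000 nM and compound 2 (`Cc1ccc(S(=O)(=O)N/N=C2\C(=O)Nc3ccc(S(=O)(=O)N4CCOCC4)cc32)cc1`) gives 261000 nM while compound 3 (`O=C1Nc2ccc(S(=O)(=O)N3CCOCC3)cc2/C1=N/c1ccc(/N=C2\C(=O)Nc3ccc(S(=O)(=O)N4CCOCC4)cc32)cc1`) gives 203000 nM on the same read-out. Compound 2 therefore stands level with the other two, since its number lies within the usual scatter of both and the three values cannot be put in any order. The three compounds carry quite different groups on the shared core, yet their numbers stay together.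

Compound 4 (`O=C1Nc2ccc(S(=O)(=O)N3CCOCC3)cc2/C1=N/NS(=O)(=O)c1ccccc1`) differs from compound 2 in one place (hydrogen in place of methyl on an aromatic carbon): hydrogen in place of methyl on an aromatic carbon, so that 4-methylphenyl becomes phenyl. Within the data shown here, no measured pair shows this change on its own, so the data give no direct size for it. The expectation rests instead on compound 2 at 261000 nM and on how closely the other two compounds sit to it. In this assay no step beyond the scatter is expected, in either direction. The estimated step of a 1.0-fold lower number from compound 2 to compound 4 (0.02 log units; within the scatter) stays within the scatter. For compound 4 the expected value is 250000 nM and the estimated range runs from 130000 nM at the low end to 450000 nM at the high end.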

Compound 4, half-maximal inhibitory concentration: 302000 nM
The estimate for compound 4 lay 1.2-fold (0.08 log units) below the measured number; the measured number falls inside the stated range.
By their numbers in this assay, from the lowest: compounds 3, 1, 2 and 4 (each within the scatter of the next).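

Among these compounds, this is the first direct reading of the change: hydrogen in place of methyl on an aromatic carbon, para to a large group, gives a 1.2-fold higher number from compound 2 to compound 4 (0.06 log units; within the scatter) in this assay and so does not separate 4-methylphenyl from phenyl at this position. Compound 4 also allows a reading at the double-bonded nitrogen, where (phenylsulfonyl)amino in place of 4-hydroxyphenyl gives a 1.2-fold higher number from compound 1 to compound 4 (0.07 log units; within the scatter) and likewise leaves the two compounds level, so neither exchange shifts the number beyond the usual scatter. Nothing at hand accounts for how small these steps are.

Whether any other group at this position would give a step beyond the scatter stays open, since the compounds shown carry only methyl and hydrogen there, and an amine, a carboxylic acid or a longer chain such as ethyl could still behave differently. From the compounds shown here alone, it is also open whether the flat picture holds when the morpholine-bearing sulfonyl group on the shared core is itself replaced, since all four compounds keep it unchanged.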